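Hydroxy on the saturated ring carbon of compound 2

The compounds below may be only part of what the source reports. "The series", "measured", "known", "first", "only" and "open" are said of these compounds alone.

Measured so far in a functional assay on A549 cells (Homo sapiens) for antiproliferative activity, read by MTT assay, with a stated time of 48 h; on this read-out lower numbers stand for stronger inhibition and higher numbers for weaker inhibition:
Compound 1 `Cc1ccc(Nc2ccc3c(c2)C(CCC(C)C)C(=O)N3)cc1` gives 6600 nM
Compound 2 `CC(C)CCC1C(=O)Nc2ccc(Nc3ccc(Cl)cc3)cc21` gives 2000 nM

Compound 2 holds the lower of the two numbers. Compound 3 `CC(C)CCC1(O)C(=O)Nc2ccc(Nc3ccc(Cl)cc3)cc21` differs from it in one place: hydroxy in place of hydrogen on a saturated ring carbon and in words this is hydroxy in place of hydrogen on a saturated ring carbon. Going by the values given here, the only measured step is a 3.3-fold lower number from compound 1 to compound 2 (0.52 log units; beyond the scatter) and it was modest, chloro in place of methyl on an aromatic carbon. That step does not touch the saturated ring carbon, so it offers only a weak guide. The expected outcome is a 1.3-fold higher number from compound 2 to compound 3 (0.10 log units; within the scatter) and no change beyond the scatter is expected in this assay for this swap. Compound 3 is estimated at 2500 nM with an expected range from 700 nM to 9000 nM on this reasoning.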

Compound 3, half-maximal inhibitory concentration: 2700 nM
Beside the measured number, compound 3's estimate is 1.1-fold (0.03 log units) below it; measured number inside the range.
By their numbers in this assay, from the lowest: compounds 2 and 3 (each within the scatter of the next); then compound 1.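

In this assay, hydroxy in place of hydrogen on the saturated ring carbon gives a 1.4-fold higher number from compound 2 to compound 3 (0.13 log units; within the scatter), so the two compounds cannot be told apart in this assay. Going by these compounds alone, this is the first reading at this position, since the earlier step concerned an aromatic carbon, and it shows that this ring carbon tolerates a hydroxy with its hydrogen-bond donor and acceptor. No measured evidence bears on this result. On these data alone, whether a methoxy or an amine on that carbon would read the same stays open, as does the effect of a longer chain there.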